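Moving the Chlorine on the Benzyl Sulfide

This account rests on a few compounds, and the source may have more. Where it says the series, first, only, none or still open, it means among the compounds named here.

Compound 1 `CC1=C(C(=O)Nc2ccc(F)cc2)C(c2ccc([N+](=O)[O-])cc2)N=C(SCc2cccc(Cl)c2)N1` and compound 2 `CC1=C(C(=O)Nc2ccc(F)cc2)C(c2ccc([N+](=O)[O-])cc2)N=C(SCc2ccc(Cl)cc2)N1` share one core and differ only by 4-chlorophenyl in place of 3-chlorophenyl on a saturated chain carbon bound to a sulfur. In a functional assay on the whole organism (artery, strain albino) with Rattus norvegicus as the target, with a stated time of 240 min, at a dose of 10 mg/kg by the oral route (a lower number here means less inhibition, a higher number more inhibition at the dose given (going by the name of the read-out)), compound 1 gives 15.9%, while compound 2 gives 33.3%, a step of a number 17.4 percentage points higher from compound 1 to compound 2 (beyond the scatter). Compound 3 `CC1=C(C(=O)Nc2ccc([N+](=O)[O-])cc2)C(c2ccc(Br)cc2)N=C(SCc2cccc(Cl)c2)N1` sits on a second core; the difference between the two cores is not broken down here. In this assay compound 3 gives 11.8%, a number within the scatter of compound 1 and beyond it from compound 2. Compound 4 `CC1=C(C(=O)Nc2ccc([N+](=O)[O-])cc2)C(c2ccc(Br)cc2)N=C(SCc2ccc(Cl)cc2)N1`, not yet measured, differs from compound 3 by 4-chlorophenyl in place of 3-chlorophenyl on a saturated chain carbon bound to a sulfur, the same change as between compound 1 and compound 2. Among the compounds with values here, the step from compound 3 to compound 4 is expected to be a number 16.2 percentage points higher from compound 3 to compound 4 (beyond the scatter), because the one precedent gave a number 17.4 percentage points higher from compound 1 to compound 2 (beyond the scatter), although a single step on another core is a thin basis. Compound 4 is therefore estimated at 28%, between 14% and 42%.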

Compound 4, a percentage reported as inhibition, in the whole organism at one dose (the size of the read-out at that dose, not a potency): 29.7%
Estimate against measurement, compound 4: 1.7 percentage points below; the measured number falls inside the stated range.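

In this assay the change from 3-chlorophenyl to 4-chlorophenyl gave a number 17.9 percentage points higher from compound 3 to compound 4 (beyond the scatter). On these two cores the change carried over with its size intact: the same change on two cores in this assay, a number 17.4 percentage points higher (beyond the scatter) from compound 1 to compound 2 and a number 17.9 percentage points higher (beyond the scatter) from compound 3 to compound 4, 0.5 percentage points apart, within the scatter of two such steps This shows that the step transferred between the two cores in this read-out, at one dose and one time, but two pairs do not show that it would hold on a further core, and they do not explain why it occurs.

The compounds shown leave open what happens when the chlorine is replaced by another group, such as a methoxy group, an amine or a carboxylic acid. They also leave open whether the step survives with a longer chain in place of the benzyl group.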